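The source may hold more compounds than are shown below. What is called first, only, known or untested is meant among the compounds shown, and "the series" means these compounds.

Compound 1 `Nc1nc(NC2CC2)c2ncn(/C=C3/CC3(CO)CO)c2n1` was tested in an ADME assay on Akata cells (Homo sapiens) for cytotoxicity, with a stated time of 7 days; a lower number here means that less compound is tolerated, a higher number that more compound is tolerated. In this assay compound 1 reaches only a limit, > 20000 nM. Compound 2 `Nc1nc(N2CCCC2)c2ncn(/C=C3/CC3(CO)CO)c2n1` also gives only a limit in this assay, > 24000 nM. Compound 3 `CSc1nc(N)nc2c1ncn2/C=C1/CC1(CO)CO` likewise shows only a limit in this assay, > 20000 nM. Two of the three values sit at the limit of > 20000 nM in this assay, at which 2 of the 3 values shown sit, and one at the limit of > 24000 nM in this assay, at which 1 of the 3 values shown sits, so the steps a step that the two limits leave unreadable from compound 1 to compound 2, a step that the two limits leave unreadable from compound 1 to compound 3 and a step that the two limits leave unreadable from compound 2 to compound 3 have no readable size; all three concern the same aromatic carbon, yet none tells how a change there moves the tolerated concentration.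

Compound 4 `CCCCCCOc1nc(N)nc2c1ncn2/C=C1/CC1(CO)CO` differs from compound 1 in one place: hexyloxy in place of cyclopropylamino on an aromatic carbon. Hexyloxy is larger than cyclopropylamino and brings no hydrogen-bond donor, but the three measured steps give no direction for such a change. The step from compound 1 to compound 4 is therefore expected to be a step that the limit leaves unreadable from compound 1 to compound 4. Compound 4 in this assay is estimated at 30000 nM, between 12000 nM and 100000 nM, and most likely the result will again be only a limit.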

Compound 4, half-maximal cytotoxic concentration: > 20000 nM
Compound 4 ended at the assay's limit; the forecaster's own chance of this, stated with the estimate: 80%; the middle value does not contradict the limit.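

In this assay compound 4 gives only a limit, > 20000 nM. Its steps to compound 1, compound 2 and compound 3 cannot be read. The compounds shown leave open whether any of these groups on this aromatic carbon changes the tolerated concentration, and in which direction.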